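A Methoxy Becomes a Hydroxy on a Shared Core

This account rests on a few compounds, and the source may have more. Where it says the series, first, only, none or still open, it means among the compounds named here.

Of the compounds shown here, three built on one shared core have been tested in a functional assay on TK-10 cells (Homo sapiens) for cytotoxicity, read by sulforhodamine B assay, with a stated time of 48 h, tested at 1 uM; a higher number here means a weaker effect of the compound at the concentration tested, a lower number a stronger effect. Compound 1 `COc1cc(C)cc(-c2c(-c3ccnc(-c4ccc(C(C)=O)cc4)c3)cnn2CC#N)c1` gives 43% in this assay. Compound 2 `Cc1cc(O)cc(-c2nn(CC#N)cc2-c2ccnc(-c3ccc(Oc4ccccc4)cc3)c2)c1` gives 19%. Compound 3 `COc1cc(C)cc(-c2nn(CC#N)cc2-c2ccnc(-c3ccc(N(C)C)cc3)c2)c1` gives 29%, which places it second highest of the three numbers: its nearest neighbour is compound 2, whose number sits within the usual scatter of it, and its furthest is compound 1, whose number lies beyond the scatter on the high side. No two of the measured compounds differ in only one place, so no single step can be read from them directly.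

Compound 4 `Cc1cc(O)cc(-c2nn(CC#N)cc2-c2ccnc(-c3ccc(N(C)C)cc3)c2)c1` has not yet been measured. It differs from compound 3 in one place: hydrogen in place of methyl on an oxygen on an aromatic ring. Cut one bond further out, the same change reads methoxy to hydroxy, or 3-methoxy-5-methylphenyl to 3-hydroxy-5-methylphenyl. Compound 2 carries this same hydroxy group together with a different group elsewhere on the core, so its value of 19% hints at, but does not settle, what the hydroxy brings here.

A change this small is expected to move the number little, and the step of a number 5 percentage points lower from compound 3 to compound 4 (within the scatter) is estimated to lie within the scatter, with no clear direction beyond it. For compound 4 the estimate in this assay is 24%, within a range from 10% to 40%.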

Compound 4, a percentage reported as activity, at one concentration (the size of the read-out at that concentration, not a potency): 44%
The estimate for compound 4 lay 20 percentage points below the measured number; the measured number lies above the stated range.
By their numbers in this assay, from the lowest: compounds 2 and 3 (each within the scatter of the next); then compounds 1 and 4 (each within the scatter of the next).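

Swapping methoxy for hydroxy on the 3-methoxy-5-methylphenyl group is not a silent change in the dimethylamino series: this assay shows a number 15 percentage points higher from compound 3 to compound 4 (beyond the scatter) and so a weaker effect at the concentration tested. With the hydroxy group held constant, dimethylamino in place of phenoxy gives a number 25 percentage points higher from compound 2 to compound 4 (beyond the scatter) and so also weakens the effect, which means that the low number of compound 2 cannot be credited to the hydroxy group alone. Nothing measured here explains why either change weakens the effect.

The compounds shown leave open whether the methoxy to hydroxy change would have the same effect with phenoxy on the core, since only the dimethylamino pair shows this step directly. They also leave open how other groups on that oxygen would behave, such as a longer chain like ethyl, or how an amine would compare if it replaced the hydroxy group on the aromatic ring.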